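The compounds below may be only part of what the source reports. "The series", "measured", "known", "first", "only" and "open" are said of these compounds alone.

In an in vitro ADME assay on microsomes from liver (Homo sapiens) for metabolic stability (on this read-out lower numbers stand for slow clearance and higher numbers for fast clearance), compound 2 (`CC(C)NC(=O)[C@H]1CC[C@@H](n2/c(=N/C(=O)c3cc(F)cc(C#N)c3)[nH]c3ccc(CN4CCC(C(C)(C)O)CC4)cc32)CC1`) gives 90 mL.min-1.g-1, within the scatter of compound 1 (`CC(C)NC(=O)[C@H]1CC[C@@H](n2/c(=N/C(=O)c3ccncc3)[nH]c3ccc(CN4CCC(C(C)(C)O)CC4)cc32)CC1`), which gives 57 mL.min-1.g-1. Compound 3 (`CC(C)NC(=O)[C@H]1CC[C@@H](n2/c(=N/C(=O)c3ccc(F)c(Cl)c3)[nH]c3ccc(CN4CCC(C(C)(C)O)CC4)cc32)CC1`) has 3-chloro-4-fluorophenyl in place of 3-cyano-5-fluorophenyl on a carbonyl carbon. Among the measured compounds shown here, the only measured change at this place, a 1.6-fold higher number from compound 1 to compound 2 (0.20 log units; within the scatter), stays within the scatter, although it swaps pyridin-4-yl for 3-cyano-5-fluorophenyl. One step is thin evidence, but no step beyond the scatter is expected in this assay, and the estimated move is a 1.1-fold lower number from compound 2 to compound 3 (0.02 log units; within the scatter). Compound 3 is expected at 85 mL.min-1.g-1, with an estimated range of 45 mL.min-1.g-1 to 150 mL.min-1.g-1.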

Compound 3, intrinsic clearance in microsomes: 83 mL.min-1.g-1
Compound 3: the middle estimate sits 1.0-fold (0.01 log units) above what was measured; measured number inside the range.
By their numbers in this assay, from the lowest: compounds 1, 3 and 2 (each within the scatter of the next).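

Swapping in 3-chloro-4-fluorophenyl gives a 1.1-fold lower number from compound 2 to compound 3 (0.04 log units; within the scatter), and the same group against pyridin-4-yl gives a 1.5-fold higher number from compound 1 to compound 3 (0.16 log units; within the scatter). In this assay, compounds 1, 2 and 3 therefore all lie within the scatter of each other, so the read-out does not separate these three aromatic groups on a carbonyl carbon, with or without the nitrile. Nothing available explains this result. As far as these compounds go, how far this holds stays open: a saturated cyclohexyl or an aminomethylphenyl on the same carbonyl carbon could fall inside or outside the scatter.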